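Fourth Compound in a Short Series of Hydrolase Inhibitors

The compounds below may be only part of what the source reports. "The series", "measured", "known", "first", "only" and "open" are said of these compounds alone.

Four compounds share one core and differ only in the group hanging from the ring amine. Compound 1 `O=c1c2cnn(-c3ccc(F)cc3)c2ncn1CC1(O)CCN(Cc2ccc(F)cc2)CC1` has no result in an assay on Sf21 cells for inhibition of ubiquitin carboxyl-terminal hydrolase 7 (Homo sapiens), read by spectrophotometry, with stated times of 30 min and 2 h; on this read-out lower numbers stand for stronger inhibition and higher numbers for weaker inhibition; for compound 1 the entry reads "not determined" (no result reported). Compound 2 `N#Cc1ccccc1CN1CCC(O)(Cn2cnc3c(cnn3-c3ccc(F)cc3)c2=O)CC1` does have one: in this assay compound 2 gives 8100 nM, a weak inhibition. Compound 3 `COC(=O)c1ccccc1CN1CCC(O)(Cn2cnc3c(cnn3-c3ccc(F)cc3)c2=O)CC1` carries a methoxycarbonyl on the benzyl ring and, like compound 1, has no number in this assay; for compound 3 the entry reads "not determined" (no result reported), so it stands without a single value, and a second entry in the series also lacks one. So the only firm point for this group of compounds is the value of compound 2.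

Compound 4 `COC(=O)c1ccc(CN2CCC(O)(Cn3cnc4c(cnn4-c4ccc(F)cc4)c3=O)CC2)c(Cl)c1` is the next member. It differs from compound 3 in one place: 2-chloro-4-(methoxycarbonyl)phenyl in place of 2-(methoxycarbonyl)phenyl on a saturated chain carbon bound to an amine nitrogen in a ring. Within the data shown here, no pair of measured compounds shows what such a change does here, so no direction can be read off. The expected step from compound 3 to compound 4 is therefore none beyond the usual scatter, with wide uncertainty in either direction.

Resting on the single known value of compound 2 8100 nM, compound 4 is expected to give about 8000 nM in this assay, with a range from 2000 nM to 30000 nM.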

Compound 4, half-maximal inhibitory concentration: 800 nM
Compound 4: middle estimate off by 10-fold (1.00 log units), on the high side; the measured number lies below the stated range.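

In this assay, the group on a saturated chain carbon bound to an amine nitrogen in a ring proves able to shift the result: 2-chloro-4-(methoxycarbonyl)phenyl in place of 2-cyanophenyl gives a 10-fold lower number from compound 2 to compound 4 (1.01 log units; beyond the scatter), a large change beyond the usual scatter. Among these compounds, this is the first measured step, and it shows that inhibition responds to what the benzyl ring carries, which a single value could not show. Neither compound 1 nor compound 3 has a number, so the steps that involve them cannot be read, and no measurement shown here gives a reason for the step that can be read.

This one step replaces the nitrile with a chlorine and a methoxycarbonyl at once, so it remains open which of the two new groups accounts for the change, a question that 4-(methoxycarbonyl)phenyl without the chlorine, or 2-chlorophenyl without the methoxycarbonyl, could help to settle. As far as these compounds go, it also remains open whether the methoxycarbonyl can give way to a carboxylic acid or a primary amide while the number stays as low as that of compound 4.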